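From 3-methoxyphenyl to naphthalen-1-yl on the shared core

The source may report more compounds than this note shows. Statements on the series, on what has been measured and on what is new or still open speak of the compounds shown alone.

Compound 1 (`O=C(Nc1ccc(Nc2ncnc3c2OCCN3)cc1)Nc1ccc(Cl)c(C(F)(F)F)c1`) and compound 2 (`COc1cccc(NC(=O)Nc2ccc(Nc3ncnc4c3OCCN4)cc2)c1`) share one core, and both are read in a functional assay on BaF3 cells (Mus musculus) for inhibition, read by MTT assay, with a stated time of 3 days; on this read-out higher numbers stand for weaker inhibition of growth and lower numbers for stronger inhibition of growth. In this assay compound 1 gives > 10000 nM, a limit of the assay and not a number. In this assay compound 2 gives > 10000 nM, also only a limit. Going by the values given here, the series so far stands at one place: the limit of > 10000 nM in this assay, at which 2 of the 2 values shown sit. Among the compounds with values here, no step between measured compounds is available.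

Compound 3 (`O=C(Nc1ccc(Nc2ncnc3c2OCCN3)cc1)Nc1cccc2ccccc12`) carries naphthalen-1-yl in place of 3-methoxyphenyl on an amide-type nitrogen.

In this assay no change beyond the scatter is expected, in either direction. This expectation rests on compound 2, which sits at the limit of > 10000 nM. The expected size of the change is a step that the limit leaves unreadable from compound 2 to compound 3. For compound 3 the estimated value is 12000 nM, with an expected range of 5000 nM to 30000 nM.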

Compound 3, concentration for 50% growth inhibition: > 10000 nM
Compound 3: only a limit was reported; the forecaster's own chance of this, stated with the estimate: 85%; the middle value does not contradict the limit.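

In this assay, going by these compounds alone, compound 3 gives > 10000 nM, a limit of the assay and not a number; compound 2 also stands only at a limit, so no step from compound 2 to compound 3 can be read. The compounds shown leave open whether any group on this amide-type nitrogen gives a readable value.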